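The compounds below may be only part of what the source reports. "The series", "measured", "known", "first", "only" and "open" are said of these compounds alone.

In a functional assay (spleen, spleen) for activation, with Mus musculus as the target (on this read-out lower numbers stand for an effect already at smaller amounts and higher numbers for an effect only at larger amounts of compound), compound 1 `Cc1nc(N)c2nc(O)n(Cc3ccccc3)c2n1` gives 1 uM. Compound 2 `CCCCCNc1nc(N)c2nc(O)n(Cc3ccccc3)c2n1` gives 0.1 uM, and compound 3 `COc1nc(N)c2nc(O)n(Cc3ccccc3)c2n1` gives 0.1 uM. Compound 3 thus stands level with compound 2 at the digits shown, the two together at the lowest numbers of the three, while a 10-fold lower number from compound 1 to compound 3 (1.00 log units; beyond the scatter) sets it apart from compound 1. Compound 4 `CCCNc1nc(N)c2nc(O)n(Cc3ccccc3)c2n1` has not yet been measured; it differs from compound 3 by propylamino in place of methoxy on an aromatic carbon. For the measured compounds named here, two steps bear on this change: a 10-fold lower number from compound 1 to compound 2 (1.00 log units; beyond the scatter) and no change at the digits printed from compound 2 to compound 3 (within the scatter). Given those two steps, a propylamino group is expected to leave the value near that of compound 3, with a 1.5-fold higher number from compound 3 to compound 4 (0.18 log units; within the scatter) expected. Compound 4 is therefore estimated at 0.15 uM, with a range from 0.05 uM to 0.5 uM.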

Compound 4, minimum effective concentration: 0.1 uM
For compound 4 the middle estimate is 1.5-fold (0.18 log units) above the measured one; the range from low to high includes it.
By their numbers in this assay, from the lowest: compounds 2, 3 and 4 (each within the scatter of the next); then compound 1.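

In this assay, propylamino on this aromatic carbon between two ring nitrogen atoms reads the same as methoxy, with no change at the digits printed from compound 3 to compound 4 (within the scatter), and the shorter chain reads the same as pentylamino, with no change at the digits printed from compound 2 to compound 4 (within the scatter). A third group now departs from methyl, with a 10-fold lower number from compound 1 to compound 4 (1.00 log units; beyond the scatter), leaving compound 1 alone apart from the other three. Nothing available explains why these different groups read alike.

Open, going by these compounds, is whether a bare amino group, a hydrogen or a carboxylic acid here would hold the same level. So is whether a chain longer than pentylamino or a piperidine ring would.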